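Long-chain series: the step to compound 4

The source may report more compounds than this note shows. Statements on the series, on what has been measured and on what is new or still open speak of the compounds shown alone.

Measured in a functional assay on MCF7 cells (Homo sapiens) for antiproliferative activity, read by MTT assay; on this read-out higher numbers stand for weaker inhibition and lower numbers for stronger inhibition:
- compound 1 `CCCCC/C=C\C/C=C\CCCCCCCc1cc(=O)c2c(O)cc(O)c(C)c2o1`: 17500 nM
- compound 2 `CC/C=C\C/C=C\C/C=C\CCCCCCCc1cc(=O)c2c(O)c(C)c(O)c(C)c2o1`: 17500 nM
- compound 3 `CCCCCCCCCCCCCCCc1cc(=O)c2c(O)cc(O)c(C)c2o1`: 17500 nM

Compound 3 stands at 17500 nM, level with compound 1 and compound 2 at the digits shown. Compound 4 `CC/C=C\C/C=C\C/C=C\CCCCCCCc1cc(=O)c2c(O)cc(O)c(C)c2o1` follows from compound 3 through (a group of 10 heavy atoms (10 carbon; no ring) in place of a group of 8 heavy atoms (8 carbon; no ring), on a saturated chain carbon, seven bonds along the chain from an aromatic carbon). The measured step that bears on this change is no change at the digits printed from compound 1 to compound 3 (within the scatter), with octyl in place of deca-1,4-dien-1-yl at the same place on the chain. That step gives no sign of movement, so no step beyond the scatter is expected in this assay, in either direction. The estimated step is no change at the digits printed from compound 3 to compound 4 (within the scatter). Compound 4 is expected at 17500 nM, with an estimated range of 9000 nM to 33000 nM.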

Compound 4, half-maximal inhibitory concentration: 17500 nM
The estimate for compound 4 equals the measured number at the digits printed; low and high end bracket the measured number.
By their numbers in this assay, from the lowest: compounds 1, 2, 3 and 4 (each within the scatter of the next).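

In this assay, the group with three double bonds in place of octyl gives no change at the digits printed from compound 3 to compound 4 (within the scatter), so this larger unsaturated group on the saturated chain carbon leaves the read-out level. Hydrogen in place of methyl on an aromatic carbon, a change outside the chain, gives no change at the digits printed from compound 2 to compound 4 (within the scatter), and but-1-en-1-yl in place of butyl gives no change at the digits printed from compound 1 to compound 4 (within the scatter). No supporting data bear on these results.

As far as these compounds go, all four compounds carry long hydrocarbon chains, so the effect of an amine or a carboxylic acid at the chain end remains open. From the compounds shown here alone, a much shorter chain also remains open.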